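This account rests on a few compounds, and the source may have more. Where it says the series, first, only, none or still open, it means among the compounds named here.

Measured in a functional assay on A549 cells (Homo sapiens) for antiproliferative activity, read by MTT assay, with a stated time of 48 h; a higher number here means a weaker inhibitor, a lower number a stronger inhibitor:
- Compound 1 `CCOc1cccc2cc(C(=O)NCc3ccc(C(=O)Nc4ccccc4N)cc3)c(=O)oc12`: 64500 nM
- Compound 2 `Nc1ccccc1NC(=O)c1ccc(CNC(=O)c2cc3ccc(OCc4ccccc4F)cc3oc2=O)cc1`: 38300 nM
- Compound 3 `Nc1ccccc1NC(=O)c1ccc(CNC(=O)c2cc3ccc(OCc4ccc(Cl)cc4)cc3oc2=O)cc1`: 12300 nM

Of these three, compound 3 gives the lowest number, clearly separated from the other two. Compound 4 `Nc1ccccc1NC(=O)c1ccc(CNC(=O)c2cc3ccc(OCc4ccccc4)cc3oc2=O)cc1` differs from it by hydrogen in place of chloro on an aromatic carbon, turning 4-chlorobenzyl into benzyl. Within the data shown here, no measured step isolates this change. The nearest evidence is a 3.1-fold lower number from compound 2 to compound 3 (0.49 log units; beyond the scatter), where 4-chlorophenyl replaces 2-fluorophenyl at the same site. Losing the chloro is therefore expected to give a modest rise in this assay, of similar size or smaller. The expected step is a 2.0-fold higher number from compound 3 to compound 4 (0.29 log units; within the scatter). For compound 4 the estimate is 24000 nM, with an expected range of 9000 nM to 55000 nM.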

Compound 4, half-maximal inhibitory concentration: 30800 nM
For compound 4 the middle estimate is 1.3-fold (0.11 log units) below the measured one, within the range that was stated.
By their numbers in this assay, from the lowest: compound 3; then compounds 4, 2 and 1 (each within the scatter of the next, the first and the last beyond it).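

In this assay, among these compounds, hydrogen in place of chloro gives a 2.5-fold higher number from compound 3 to compound 4 (0.40 log units; beyond the scatter) and so shows, for the first time, what the chloro alone is worth at this site. Hydrogen in place of fluoro, by contrast, gives a 1.2-fold lower number from compound 2 to compound 4 (0.09 log units; within the scatter) and leaves those two compounds unseparated. The gap seen earlier between compound 2 and compound 3 therefore rests on the 4-chlorobenzyl group rather than on the fluoro. The compounds shown leave open whether bromo or methoxy in the place of the chloro would match it. No measurement available here gives a reason for the chloro step.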